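From 4-methylphenyl to 3-chlorophenyl on the ring nitrogen

The source may hold more compounds than are shown below. What is called first, only, known or untested is meant among the compounds shown, and "the series" means these compounds.

Of the compounds shown here, two with the same core have been measured so far in a functional assay on HepG2 cells (Homo sapiens) for inhibition, read by MTT assay, with a stated time of 72 h; on this read-out higher numbers stand for weaker inhibition and lower numbers for stronger inhibition. For the measured compounds named here, compound 1 `Cc1ccc(-n2c(-c3coc4cc(C)c(Cl)cc4c3=O)nc(-c3ccccc3)c2-c2ccccc2)c(C)c1` gives 3120 nM, and compound 2 `Cc1ccc(-n2c(-c3coc4cc(C)c(Cl)cc4c3=O)nc(-c3ccccc3)c2-c2ccccc2)cc1` gives 6250 nM, which places compound 2 within the scatter of compound 1, its only measured neighbour. Compound 3 `Cc1cc2occ(-c3nc(-c4ccccc4)c(-c4ccccc4)n3-c3cccc(Cl)c3)c(=O)c2cc1Cl` differs from compound 2 by one swap, 3-chlorophenyl in place of 4-methylphenyl on an aromatic nitrogen. Going by the values given here, only one measured step touches that same aromatic group: a 2.0-fold higher number from compound 1 to compound 2 (0.30 log units; within the scatter), with hydrogen in place of methyl on an aromatic carbon. Among the compounds with values here, no measured compound yet carries chlorine on this group, so that small step is a limited guide. Even so, no change beyond the scatter is expected, and the expected step is a 1.3-fold lower number from compound 2 to compound 3 (0.10 log units; within the scatter). Compound 3 is estimated at 5000 nM, with an expected range of 2000 nM to 12500 nM.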

Compound 3, half-maximal inhibitory concentration: 25000 nM
For compound 3 the middle estimate is 5.0-fold (0.70 log units) below the measured one; measured number outside the range, above it.
By their numbers in this assay, from the lowest: compounds 1 and 2 (each within the scatter of the next); then compound 3.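

In this assay, the group on the ring nitrogen proves able to move the number beyond the scatter: 3-chlorophenyl in place of 4-methylphenyl gives a 4.0-fold higher number from compound 2 to compound 3 (0.60 log units; beyond the scatter), whereas the earlier loss of one methyl from this group stayed within the scatter. Set against 2,4-dimethylphenyl, the same 3-chlorophenyl group gives an 8.0-fold higher number from compound 1 to compound 3 (0.90 log units; beyond the scatter), so among these three compounds, the chlorine-bearing group goes with the weakest inhibition. No measurement shown here explains this shift.

The swap removes methyl and brings in chlorine at a different place on the phenyl ring, so the effect of the atom cannot be separated from that of its place; 4-chlorophenyl or 3-methylphenyl would help to separate them. On these data alone, how an amine or a carboxylic acid on this phenyl ring would read also remains open.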